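The source may report more compounds than this note shows. Statements on the series, on what has been measured and on what is new or still open speak of the compounds shown alone.

Compound 1 `N#C[Se]c1ccc(NC(=O)OCc2ccc([N+](=O)[O-])cc2)cc1` gives 6000 nM in an ADME assay on 184B5 cells (Homo sapiens) for cytotoxicity, read by MTT assay, with a stated time of 72 h; a higher number here means a weaker inhibitor of growth, a lower number a stronger inhibitor of growth. Compound 2 `N#C[Se]c1ccc(NC(=O)OCc2ccccc2)cc1` gives 5000 nM. Compound 3 `N#C[Se]c1ccc(NC(=O)OCC2=Cc3ccccc3S2(=O)=O)cc1` gives 5300 nM.

Compound 2 has the lowest of the three numbers, but its gaps to compound 3 and to compound 1 are both within the scatter, so the three measured compounds cannot be ranked against each other. For the measured compounds named here, the only measured step, a 1.2-fold lower number from compound 1 to compound 2 (0.08 log units; within the scatter), alters the ring of the benzyl group and changes nothing beyond the scatter.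

Compound 4 `CCCCOC(=O)Nc1ccc([Se]C#N)cc1` differs from compound 2 by propyl in place of phenyl on a saturated chain carbon bound to an oxygen next to a carbonyl group. Going by the values given here, no measured step exchanges the whole ring for a chain; the one step that touches this part of the molecule, the one from compound 1 to compound 2, stayed within the scatter, and the other carbamate variant, compound 3, also sits close to compound 2. On this evidence a step no larger than the scatter is expected, with no direction favoured, so the estimated step is no change at the digits printed from compound 2 to compound 4 (within the scatter). Compound 4 is therefore expected to give about 5000 nM, within a range of 2500 nM to 10000 nM.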

Compound 4, concentration for 50% growth inhibition: 5300 nM
For compound 4 the middle estimate is 1.1-fold (0.03 log units) below the measured one; the range from low to high includes it.
By their numbers in this assay, from the lowest: compounds 2, 3, 4 and 1 (each within the scatter of the next).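

In this assay the step from phenyl to propyl on a saturated chain carbon bound to an oxygen next to a carbonyl group gives a 1.1-fold higher number from compound 2 to compound 4 (0.03 log units; within the scatter). The earlier step only replaced a nitro group on the ring, whereas this one removes the whole six-membered aromatic ring of carbon and still stays within the scatter, so for this pair the aromatic ring is not needed to keep the number where it stands. No available evidence explains why the number holds across this change.

As far as these compounds go, whether an amine, a carboxylic acid or a longer chain at this place would move the number beyond the scatter remains open. The compounds shown also leave open what a change in the rest of the shared core would do.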